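Prenyl chain length and ether swap on a pyridinone core

The source may hold more compounds than are shown below. What is called first, only, known or untested is meant among the compounds shown, and "the series" means these compounds.

Measured compounds:
Compound 1 `CC(C)=CCC1Cc2c(OCCCNC(=O)c3ccc([N+](=O)[O-])cc3)cc(=O)n(CCCO)c2CC1(C)C` in a functional assay on PANC-1 cells (Homo sapiens) for inhibition, read by MTT assay, with a stated time of 24 h, tested at 10 uM (a higher number here means more inhibition at the concentration tested (going by the name of the read-out), a lower number less inhibition), gives 49.9%.
Compound 2 `COc1ccc(OCCCOc2cc(=O)n(CCCO)c3c2CC(CC=C(C)C)C(C)(C)C3)cc1` in this assay gives 47.7%.
Compound 3 `CC(C)=CCC/C(C)=C/CC1Cc2c(OCCCNC(=O)c3ccc([N+](=O)[O-])cc3)cc(=O)n(CCCO)c2CC1(C)C` in this assay gives 16.8%.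

Compound 4 `COc1ccc(OCCCOc2cc(=O)n(CCCO)c3c2CC(C/C=C(\C)CCC=C(C)C)C(C)(C)C3)cc1` has not yet been measured in this assay. It is related to compound 3 by one change, (4-methoxyphenoxy in place of ((4-nitrophenyl)carbonyl)amino on a saturated chain carbon, three bonds along the chain from an oxygen on an aromatic ring). The same change appears once before among these compounds, from compound 1 to compound 2: 4-methoxyphenoxy in place of ((4-nitrophenyl)carbonyl)amino on a saturated chain carbon, three bonds along the chain from an oxygen on an aromatic ring. There the step was a number 2.2 percentage points lower from compound 1 to compound 2 (within the scatter), so the two values of compound 1 and compound 2 show no difference that can be told apart from the usual scatter.

The cores of compound 3 and compound 4 differ from those of compound 1 and compound 2 in one counted way: 3-methylbut-2-en-1-yl in place of hydrogen on a saturated chain carbon bound to a double-bonded chain carbon. That change carried a large step, a number 33.1 percentage points lower from compound 1 to compound 3 (beyond the scatter), leaving compound 3 with the lowest of the three measured numbers.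

Compound 4 therefore combines the longer chain of compound 3 with the ether end of compound 2. The step from compound 3 to compound 4 in this assay is expected to be small, about a number 1.8 percentage points lower from compound 3 to compound 4 (within the scatter), because the same change gave a number 2.2 percentage points lower from compound 1 to compound 2 (within the scatter) on the shorter-chain core. On that basis compound 4 is estimated at 15%, most likely between 3% and 30%. Among the measured compounds shown here, only one prior example of the change exists, so this rests on a single comparison.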

Compound 4, a percentage reported as inhibition, at one concentration (the size of the read-out at that concentration, not a potency): 20%
The estimate for compound 4 lay 5 percentage points below the measured number, and the stated range covers the measured number.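

In this assay, 4-methoxyphenoxy in place of ((4-nitrophenyl)carbonyl)amino gave a number 3.2 percentage points higher from compound 3 to compound 4 (within the scatter) on the core with the longer chain, so this exchange again left no difference that can be told from the scatter, and the two cores agree: the same change on two cores in this assay, a number 2.2 percentage points lower (within the scatter) from compound 1 to compound 2 and a number 3.2 percentage points higher (within the scatter) from compound 3 to compound 4, 5.4 percentage points apart, within the scatter of two such steps.

The chain change carried over as well, since 3-methylbut-2-en-1-yl in place of hydrogen gave a number 27.7 percentage points lower from compound 2 to compound 4 (beyond the scatter) with the 4-methoxyphenoxy end, a drop of about the same size as the one seen with the ((4-nitrophenyl)carbonyl)amino end: the same change on two cores in this assay, a number 33.1 percentage points lower (beyond the scatter) from compound 1 to compound 3 and a number 27.7 percentage points lower (beyond the scatter) from compound 2 to compound 4, 5.4 percentage points apart, within the scatter of two such steps.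

Across these four compounds the two changes therefore add up without visible interference, but this rests on only two cores and two end groups, at a single concentration in one cell line, and it does not show that the exchange would stay silent on any other core or at any other concentration.

The compounds shown leave open how an end group of another kind, such as an amine or a carboxylic acid, would behave at this place on the chain. They also leave open whether a saturated chain of the same length as the longer one would bring the same drop as the chain in compound 3 and compound 4.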